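Halogen exchange on the shared core: expectation for compound 3

A few compounds are considered here, and "the series" means these few. Any claim that something is new, unique, unknown or untested is made for them only; others in the source may bear on it.

Measured so far:
- compound 1, `O=C(O)/C(S)=C/c1c[nH]c2cc(Cl)ccc12`: 100 nM
- compound 2, `O=C(O)/C(S)=C/c1c[nH]c2cccc(F)c12`: 300 nM

In an assay on isolated protein for inhibition of Calpain-1 catalytic subunit (Sus scrofa) (on this read-out lower numbers stand for stronger inhibition and higher numbers for weaker inhibition), compound 1 gives 100 nM. In the same assay compound 2 gives 300 nM, the higher of the two numbers, and the gap between the two compounds lies beyond the usual scatter, so compound 2 shows the weaker inhibition of the pair. The two compounds differ in more than one place, so nothing is known about how much of that gap belongs to the kind of halogen and how much to where it sits.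

Compound 3, `O=C(O)/C(S)=C/c1c[nH]c2cccc(Br)c12`, has not yet been measured. It differs from compound 2 in one respect: bromo in place of fluoro on an aromatic carbon. For the measured compounds named here, no measured pair in this set shows what such an exchange does, so the size and direction of the step can only be guessed. The expectation is a modest step, if any, from compound 2 to compound 3, estimated as a 1.5-fold lower number from compound 2 to compound 3 (0.18 log units; within the scatter), with the direction uncertain. For compound 3 the estimated value in this assay is 200 nM, within a range from 60 nM to 700 nM.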

Compound 3, half-maximal inhibitory concentration: 100 nM
Compound 3: middle estimate off by 2.0-fold (0.30 log units), on the high side; low and high end bracket the measured number.
By their numbers in this assay, from the lowest: compounds 1 and 3 (each within the scatter of the next); then compound 2.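

In this assay, bromo in place of fluoro on an aromatic carbon, ortho to a fused ring and meta to a fused ring on the six-membered aromatic ring, gives a 3.0-fold lower number from compound 2 to compound 3 (0.48 log units; beyond the scatter). For the compounds shown here, this is the first change confined to one place, and it shows that this position is not indifferent to the kind of halogen: with the rest of the molecule held constant, bromo gives stronger inhibition than fluoro, by a step beyond the scatter. The data give no measurement that could explain this step.

Going by these compounds, with only fluoro and bromo at this position, it remains open whether the trend runs through chloro or iodo, and whether either halogen improves on plain hydrogen, which would show if fluoro weakens inhibition, bromo strengthens it, or both. On these data alone, it also remains open whether a non-halogen group such as methyl, methoxy or an amine is accepted here, and how much of the gap between compounds 1 and 2 belongs to the position, which would take chloro at this position or bromo at the place the chloro occupies in compound 1.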